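Swapping Trifluoromethyl for Trifluoromethoxy on a Thiourea Series

This account rests on a few compounds, and the source may have more. Where it says the series, first, only, none or still open, it means among the compounds named here.

In an assay on isolated protein for binding affinity to stress-70 protein, mitochondrial (Homo sapiens) (on this read-out higher numbers stand for weaker binding and lower numbers for tighter binding), compound 1 `CC1(C)CCNc2ccc(NC(=S)Nc3ccc(C(F)(F)F)cc3)cc21` gives 3300 nM. Compound 2 `CC1(C)CCNc2ccc(NC(=S)Nc3ccc(OC(F)(F)F)cc3)cc21` differs from compound 1 by trifluoromethoxy in place of trifluoromethyl on an aromatic carbon; in this assay compound 2 gives 5400 nM, which means a 1.6-fold higher number from compound 1 to compound 2 (0.21 log units; within the scatter). Compound 3 `CN1c2ccc(NC(=S)Nc3ccc(C(F)(F)F)cc3)cc2C(C)(C)C(O)C1(C)C` is built on a different core; the difference between the two cores is not broken down here. In this assay compound 3 gives 2300 nM. Compound 4 `CN1c2ccc(NC(=S)Nc3ccc(OC(F)(F)F)cc3)cc2C(C)(C)C(O)C1(C)C` has not been measured; it differs from compound 3 by trifluoromethoxy in place of trifluoromethyl on an aromatic carbon, the same change that turned compound 1 into compound 2, made at the same place. Because a 1.6-fold higher number from compound 1 to compound 2 (0.21 log units; within the scatter) lies within the usual scatter, an equally small step is expected for compound 4 as well: a 1.6-fold higher number from compound 3 to compound 4 (0.19 log units; within the scatter). Compound 4 is therefore estimated at 3600 nM, with a likely range from 1800 nM to 7500 nM.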

Compound 4, dissociation constant: 2900 nM
For compound 4 the middle estimate is 1.2-fold (0.09 log units) above the measured one, and the stated range covers the measured number.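

In this assay, trifluoromethoxy in place of trifluoromethyl gives a 1.3-fold higher number from compound 3 to compound 4 (0.10 log units; within the scatter) and so leaves the number on this second core within the usual scatter. The two cores agree on the size of this step: the same change on two cores in this assay, a 1.6-fold higher number (0.21 log units; within the scatter) from compound 1 to compound 2 and a 1.3-fold higher number (0.10 log units; within the scatter) from compound 3 to compound 4, 1.3-fold (0.11 log units) apart, within the scatter of two such steps. This shows that, across these two pairs, the swap carries from one core to the other without a detectable shift; it does not show that the same would hold on any further core, and steps this small cannot show that the swap has a real effect on binding at all.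

The compounds shown leave open what a clearly different group in this place, such as a nitrile, an amine or a carboxylic acid, would do on either core. They also leave open which part of the difference between the two cores matters for binding.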